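Two amides at the assay limit, one new dimethylamide

A few compounds are considered here, and "the series" means these few. Any claim that something is new, unique, unknown or untested is made for them only; others in the source may bear on it.

Measured so far in a functional assay on A549 cells (Homo sapiens) for inhibition, read by sulforhodamine B assay, with a stated time of 72 h; on this read-out lower numbers stand for stronger inhibition of growth and higher numbers for weaker inhibition of growth:
- Compound 1 `COC1CN(C(=O)/C=C/c2ccncc2-c2ccc3ccccc3c2)C1` gives > 10000 nM, which is a limit of the assay rather than a number.
- Compound 2 `O=C(O)/C=C/c1ccncc1-c1ccc2[nH]ccc2c1` gives > 10000 nM, again a limit and not a number.

Compound 1 therefore stands at the limit of this assay, and the limit of > 10000 nM in this assay, at which 2 of the 2 values shown sit, shows that compound 2 sits at the same limit. Going by the values given here, neither compound shows growth inhibition that could be measured within the tested range, and no step between two measured compounds is available from which to learn anything. Compound 3 `CN(C)C(=O)/C=C/c1ccncc1-c1ccc2ccccc2c1` differs from compound 1 in one place: dimethylamino in place of 3-methoxyazetidin-1-yl on a carbonyl carbon. The group that enters is smaller and carries no ring, but the data hold no measured change of this kind from which to read its effect. With both measured compounds at the limit, no movement beyond the scatter is expected in either direction, and the most likely outcome is that compound 3 also reports only a limit. The estimate for compound 3 is 15000 nM, within 3000 nM to 60000 nM. The expected step that the limit leaves unreadable from compound 1 to compound 3 is thus essentially none.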

Compound 3, concentration for 50% growth inhibition: 5800 nM
For compound 3 the middle estimate is 2.6-fold (0.41 log units) above the measured one; low and high end bracket the measured number.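

In this assay, going by these compounds alone, compound 3 gives 5800 nM, the first real number rather than a limit, so growth inhibition can be measured with dimethylamino on this carbonyl carbon. Replacing 3-methoxyazetidin-1-yl with dimethylamino gives an at least 1.7-fold lower number from compound 1 to compound 3 (0.23 log units; that floor lies within the scatter), so the data show only a minimum for this step, and that minimum does not clear the normal variation between repeat measurements. Compound 1 remains a limit of the assay, so the true size of the step cannot be read, and most of the series still sits at that ceiling: the limit of > 10000 nM in this assay, at which 2 of the 3 values shown sit.

This single change removes the ring and the methoxy group together, so the compounds shown cannot separate their contributions; a plain azetidin-1-yl group, which keeps the ring without the methoxy, would be the direct comparison. On these data alone, it also remains open whether other amines on this carbonyl carbon, such as diethylamino, pyrrolidin-1-yl or morpholin-4-yl, would give numbers clearly different from that of compound 3.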